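The source may hold more compounds than are shown below. What is called first, only, known or untested is meant among the compounds shown, and "the series" means these compounds.

Compound 2, `CCOC(=O)c1c(C)[nH]c(=O)c(C#N)c1-c1ccc(F)cc1`, gives the lower of the two numbers seen so far in an ADME assay on MRC5 cells (Homo sapiens) for cytotoxicity, read by MTT assay, with a stated time of 24 h; a higher number here means a weaker inhibitor, a lower number a stronger inhibitor: compound 2 gives 149000 nM. Among the compounds with values here, the only other measured compound, compound 1, `CCOC(=O)c1c(C)[nH]c(=O)c(C#N)c1-c1ccc([N+](=O)[O-])cc1`, gives 2230000 nM in this assay, and the single measured step, a 15-fold lower number from compound 1 to compound 2 (1.18 log units; beyond the scatter), separates the two.

Compound 3, `CCOC(=O)c1c(C)[nH]c(=O)c(C#N)c1-c1ccc(Br)cc1`, is the next compound to be measured. It differs from compound 2 in one place: bromo in place of fluoro on an aromatic carbon, on an aromatic carbon of a six-membered aromatic ring of carbon only, para to a large group. Cut one bond further out, the change reads 4-fluorophenyl to 4-bromophenyl.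

Within the data shown here, no measured step in this assay exchanges one halogen for another, so the step from compound 1 to compound 2 tells only that a change at this position can move the number a long way. With nothing closer to rest on, the number for compound 3 is expected to stay near that of compound 2, and the step of a 1.5-fold lower number from compound 2 to compound 3 (0.17 log units; within the scatter) is an estimate rather than a trend. Compound 3 is therefore estimated at 100000 nM, within a range from 30000 nM to 400000 nM.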

Compound 3, half-maximal inhibitory concentration: 310000 nM
Beside the measured number, compound 3's estimate is 3.1-fold (0.49 log units) below it; low and high end bracket the measured number.
By their numbers in this assay, from the lowest: compound 2; then compound 3; then compound 1.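

In this assay, within the data shown here, this is the first measured exchange of one halogen for another at this position: a 2.1-fold higher number from compound 2 to compound 3 (0.32 log units; beyond the scatter), a step only just beyond the scatter but enough to show that the two halogens do not give the same number here. Bromo in place of nitro gives a lower number as fluoro does, with a 7.2-fold lower number from compound 1 to compound 3 (0.86 log units; beyond the scatter), so among these three compounds the number rises from the fluoro compound through the bromo compound to the nitro compound. No measurement bearing on why the numbers fall in this order is available.

Going by these compounds, it remains open whether the other halogens, chloro and iodo, would fit this order, and where a non-halogen such as an amine or a methoxy group on the same aromatic carbon would fall relative to these three compounds. The shared core is also unchanged across all three compounds, so how a carboxylic acid in place of the ethyl ester would affect the number in this assay cannot be told from them.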